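A Sulfonamide Substituent Change and Expected Cytotoxicity

The compounds below may be only part of what the source reports. "The series", "measured", "known", "first", "only" and "open" are said of these compounds alone.

Measured so far in a functional assay on A549 cells (Homo sapiens) for cytotoxicity, read by sulforhodamine B assay, with a stated time of 72 h; on this read-out higher numbers stand for weaker inhibition and lower numbers for stronger inhibition:
Compound 1, `Cc1cc(NS(=O)(=O)c2ccc(NCc3coc4ccccc4c3=O)cc2)no1`, gives 59700 nM.
Compound 2, `NS(=O)(=O)c1ccc(NC2=NC(=O)/C(=C\c3coc4ccccc4c3=O)S2)cc1`, gives 2230 nM.
Compound 3, `CCOC1Oc2ccccc2C(=O)/C1=C/Nc1ccc(S(=O)(=O)Nc2cc(C)on2)cc1`, gives 57200 nM.

Compound 2 stands lowest of the three numbers in this assay; compound 3 and compound 1 both give higher numbers, beyond the scatter, so compound 2 is the strongest inhibitor here. Compound 4, `Cc1cc(C)nc(NS(=O)(=O)c2ccc(NC3=NC(=O)/C(=C\c4coc5ccccc5c4=O)S3)cc2)n1`, keeps the whole of compound 2 and differs in one place: 4,6-dimethylpyrimidin-2-yl in place of hydrogen on a sulfonamide nitrogen. Among the measured compounds shown here, no measured pair shows what such a change does, since compounds 1 and 3 differ from compound 2 in more than this one place. The step from compound 2 to compound 4 in this assay is therefore expected to be small, near the scatter, with a slight lean toward weaker inhibition: a 1.4-fold higher number from compound 2 to compound 4 (0.16 log units; within the scatter). Compound 4 is estimated at 3200 nM, within 900 nM to 12000 nM.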

Compound 4, half-maximal inhibitory concentration: > 100000 nM
Compound 4: only a limit was reported; the forecaster's own chance of this, stated with the estimate: 5%; middle value at least 31-fold (1.49 log units) away from the limit.
By their numbers in this assay, from the lowest: compound 2; then compounds 3 and 1 (each within the scatter of the next). At a limit, above all of these: compound 4.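

Among the compounds shown here, this is the first pair that changes only the sulfonamide nitrogen. In this assay, putting 4,6-dimethylpyrimidin-2-yl in place of hydrogen there gives an at least 44-fold higher number from compound 2 to compound 4 (1.65 log units; beyond the scatter), so inhibition in this assay depends strongly on what this nitrogen carries, and this group is not accepted there. Compound 4 gives > 100000 nM, which is a limit and not a number.

The compounds shown leave open whether a methyl or acetyl group on this nitrogen would keep the value of compound 2. They also leave open how a simple phenyl ring there would compare.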